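This account rests on a few compounds, and the source may have more. Where it says the series, first, only, none or still open, it means among the compounds named here.

Measured so far in a functional assay on C6 cells (Rattus norvegicus) for inhibition, read by sulforhodamine B assay, with a stated time of 72 h; a lower number here means that less compound is needed, a higher number that more compound is needed for the effect:
- Compound 1 `O=C(/C=C/c1ccc([N+](=O)[O-])o1)c1ccc(Br)cc1`: 2700 nM
- Compound 2 `CSc1ccc(C(=O)/C=C/c2ccc([N+](=O)[O-])o2)cc1`: 1600 nM

Going by the values given here, compound 2, at 1600 nM, has only one neighbour on these numbers: compound 1, at 2700 nM. The two lie within the usual scatter of each other, so neither stands apart.

Compound 3 `O=C(/C=C/c1ccc([N+](=O)[O-])o1)c1ccc(N2CCNCC2)cc1` has not yet been measured in this assay. It carries piperazin-1-yl in place of methylsulfanyl on an aromatic carbon, para to a large group: piperazin-1-yl in place of methylsulfanyl on an aromatic carbon.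

Among the compounds with values here, only one measured step bears on this change: a 1.7-fold lower number from compound 1 to compound 2 (0.23 log units; within the scatter). It swaps bromo for methylsulfanyl on an aromatic carbon and stays within the scatter. That is thin evidence, as neither of these groups contains a ring like the one in piperazin-1-yl. The data therefore suggest no direction, and no step beyond the scatter is expected in this assay, although the uncertainty is wide. The expected change is a 1.3-fold higher number from compound 2 to compound 3 (0.10 log units; within the scatter).

For compound 3 the estimated value is 2000 nM, with an expected range from 500 nM to 8000 nM.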

Compound 3, half-maximal effective concentration: 1500 nM
Compound 3: the middle estimate sits 1.3-fold (0.12 log units) above what was measured, and the stated range covers the measured number.
By their numbers in this assay, from the lowest: compounds 3, 2 and 1 (each within the scatter of the next).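

In this assay, placing piperazin-1-yl on this aromatic carbon, para to a large group, gives a 1.1-fold lower number from compound 2 to compound 3 (0.03 log units; within the scatter), and the comparison with the bromo compound gives a 1.8-fold lower number from compound 1 to compound 3 (0.26 log units; within the scatter); both steps lie within the scatter. The earlier pair only exchanged bromo and methylsulfanyl, neither of which contains a ring, whereas this result shows that a six-membered non-aromatic ring carrying a hydrogen-bond donor can stand at this position without moving the number beyond the scatter. No measurement at hand speaks to what lies behind this flat result.

Going by these compounds, it remains open whether an open-chain amine, a carboxylic acid or a longer chain on this same carbon would also leave the number within the scatter, or whether only some groups are tolerated here. These compounds also share the rest of their structure, so they cannot show what would happen if the nitro group of the shared core gave way to another group, such as a nitrile.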